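Trimethoxy to Dimethoxy on the Aryl Ring of a Thiazolidinedione

The source may report more compounds than this note shows. Statements on the series, on what has been measured and on what is new or still open speak of the compounds shown alone.

Measured compounds:
- compound 1, `COc1cc(-c2nc3cc(/C=C4\SC(=O)NC4=O)ccc3[nH]2)cc(OC)c1OC`: 3570 nM
- compound 2, `COc1ccc(-c2nc3cc(/C=C4\SC(=O)NC4=O)ccc3[nH]2)cc1OC`: 570 nM
- compound 3, `COc1cc(-c2nc3cc(/C=C4\SC(=O)N(CC(=O)N5CCOCC5)C4=O)ccc3[nH]2)cc(OC)c1OC`: 2930 nM

In a functional assay on A549 cells (Homo sapiens) for inhibition, read by MTT assay, with a stated time of 48 h (on this read-out lower numbers stand for stronger inhibition and higher numbers for weaker inhibition), compound 1 gives 3570 nM and compound 2 gives 570 nM. The two differ by hydrogen in place of methoxy on an aromatic carbon, a change that produced a 6.3-fold lower number from compound 1 to compound 2 (0.80 log units; beyond the scatter). Compound 3 carries a different core: it differs from compound 1 by ((morpholin-4-yl)carbonyl)methyl in place of hydrogen on an amide-type nitrogen in a ring, and that change produced a 1.2-fold lower number from compound 1 to compound 3 (0.09 log units; within the scatter), so compound 3, at 2930 nM, stands close to compound 1 in this assay.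

Compound 4, `COc1ccc(-c2nc3cc(/C=C4\SC(=O)N(CC(=O)N5CCOCC5)C4=O)ccc3[nH]2)cc1OC`, has not been measured. It differs from compound 3 by hydrogen in place of methoxy on an aromatic carbon, the same change that led from compound 1 to compound 2, made at the same place. Among the measured compounds shown here, only one measured example of this change exists, so the expectation rests on that single pair. Since compound 3 in this assay sits where compound 1 does, the expected step is a 5.3-fold lower number from compound 3 to compound 4 (0.73 log units; beyond the scatter), slightly tempered against the earlier one. How this change behaves on the core of compound 3 has not been measured. Compound 4 is therefore estimated at 550 nM, between 250 nM and 1300 nM.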

Compound 4, half-maximal inhibitory concentration: 8930 nM
Estimate against measurement, compound 4: 16-fold (1.21 log units) below, outside the stated range (above it).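

In this assay, hydrogen in place of methoxy on an aromatic carbon gave a 3.0-fold higher number from compound 3 to compound 4 (0.48 log units; beyond the scatter), a step opposite in direction to the one seen on the core of compound 1, so the change did not carry from one core to the other: the same change on two cores in this assay, a 6.3-fold lower number (0.80 log units; beyond the scatter) from compound 1 to compound 2 and a 3.0-fold higher number (0.48 log units; beyond the scatter) from compound 3 to compound 4, 19-fold (1.28 log units) apart, beyond the scatter of two such steps Read from the other side, ((morpholin-4-yl)carbonyl)methyl in place of hydrogen on the amide-type nitrogen gave a 16-fold higher number from compound 2 to compound 4 (1.19 log units; beyond the scatter), so the effect of this group also depends on whether the aryl ring is 3,4,5-trimethoxyphenyl or 3,4-dimethoxyphenyl: the same change on two cores in this assay, a 1.2-fold lower number (0.09 log units; within the scatter) from compound 1 to compound 3 and a 16-fold higher number (1.19 log units; beyond the scatter) from compound 2 to compound 4, 19-fold (1.28 log units) apart, beyond the scatter of two such steps This shows that the two changes do not act independently in these four compounds, but it rests on a single set of paired steps and does not show why they interact or whether the reversal extends to any other compound in the series.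

The compounds shown leave open whether the reversal persists with another group on that nitrogen, such as a piperazine amide or a carboxylic acid. They also leave open whether a hydroxy group or a fluorine in place of the methoxy would behave as hydrogen does on either core.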